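This account rests on a few compounds, and the source may have more. Where it says the series, first, only, none or still open, it means among the compounds named here.

Compound 1 `COc1ccc(/C=C/C(=O)OC[C@@H](OCc2ccccc2)[C@H]2OC(=O)C=C[C@H]2OCc2ccccc2)cc1` and compound 2 `O=C1C=C[C@@H](OCc2ccccc2)[C@@H]([C@@H](COC(=O)/C=C/c2ccc(F)cc2)OCc2ccccc2)O1` share one core, and in a functional assay on K562 cells (Homo sapiens) for antiproliferative activity, read by MTT assay, with a stated time of 6 days (on this read-out higher numbers stand for weaker inhibition and lower numbers for stronger inhibition), compound 1 gives 430 nM while compound 2 gives 1010 nM. The change between them, (fluoro in place of methoxy on an aromatic carbon), produced a 2.3-fold higher number from compound 1 to compound 2 (0.37 log units; beyond the scatter). Compound 3 `COc1ccc(/C=C/C(=O)OC[C@@H](OC(C)=O)[C@H]2OC(=O)C=C[C@H]2OC(C)=O)cc1` carries a second core; the difference between the two cores is not broken down here. In this assay compound 3 gives 6960 nM, the highest of the three numbers. Compound 4 `CC(=O)O[C@@H]1C=CC(=O)O[C@@H]1[C@@H](COC(=O)/C=C/c1ccc(F)cc1)OC(C)=O` differs from compound 3 by fluoro in place of methoxy on an aromatic carbon, the same change made on the same kind of position as from compound 1 to compound 2. Compound 4 is expected to show a 2.2-fold higher number from compound 3 to compound 4 (0.33 log units; beyond the scatter), resting on the step seen from compound 1 to compound 2, a 2.3-fold higher number from compound 1 to compound 2 (0.37 log units; beyond the scatter), so a comparable movement is estimated here. In this assay compound 4 is therefore estimated at 15000 nM, between 6000 nM and 40000 nM.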

Compound 4, half-maximal inhibitory concentration: 3460 nM
Beside the measured number, compound 4's estimate is 4.3-fold (0.64 log units) above it; the measured number lies below the stated range.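

In this assay, fluoro in place of methoxy gives a 2.0-fold lower number from compound 3 to compound 4 (0.30 log units; within the scatter), so on the core of compound 3 the change produces no step beyond the scatter. Set beside the same change on the core of compound 1, the two results differ: the same change on two cores in this assay, a 2.3-fold higher number (0.37 log units; beyond the scatter) from compound 1 to compound 2 and a 2.0-fold lower number (0.30 log units; within the scatter) from compound 3 to compound 4, 4.7-fold (0.67 log units) apart, beyond the scatter of two such steps. This shows that the step seen on one core did not carry over unchanged to the other in this series, but with a single pair on each core it does not show why the cores differ or how any other change would carry over.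

The compounds shown leave open whether an amine or a chloro group in that same place would behave alike on both cores. On these data alone, it also remains open how the change would read on a core bearing longer chains.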